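This account rests on a few compounds, and the source may have more. Where it says the series, first, only, none or still open, it means among the compounds named here.

Compound 1 `O=C(/C=C\Nc1cnc2ccccc2c1)c1nc(-c2ccccc2)n2ccccc12` and compound 2 `O=C(/C=C\Nc1ccc(Cl)cc1)c1nc(-c2ccc(C(F)(F)F)cc2)n2ccccc12` share one core and were tested in a functional assay on HCT-116 cells (Homo sapiens) for cytotoxicity, read by MTT assay, with a stated time of 48 h; on this read-out lower numbers stand for stronger inhibition and higher numbers for weaker inhibition. Compound 1 reaches only the limit of the assay, giving > 30000 nM. Among the compounds with values here, compound 2 gives 11500 nM, the only number in this assay. The other value, that of compound 1, is the limit of > 30000 nM in this assay, at which 1 of the 2 values shown sits. Compound 3 `O=C(/C=C\Nc1cnc2ccccc2c1)c1nc(-c2ccc(C(F)(F)F)cc2)n2ccccc12` differs from compound 2 by quinolin-3-yl in place of 4-chlorophenyl on an amine nitrogen, the quinolin-3-yl being the group compound 1 also carries. Within the data shown here, no measured step covers this change. The writer expects a step of a 2.2-fold higher number from compound 2 to compound 3 (0.34 log units; beyond the scatter) toward weaker inhibition, beyond the usual scatter, and estimates compound 3 at 25000 nM, ranging from 8000 nM to 80000 nM.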

Compound 3, half-maximal inhibitory concentration: > 30000 nM
Compound 3: no number, only a limit; the forecaster's own chance of this, stated with the estimate: 40%; at least 1.2-fold (0.07 log units) between middle value and limit.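

In this assay, within the data shown here, the first readable change at this amine nitrogen gives an at least 2.6-fold higher number from compound 2 to compound 3 (0.41 log units; beyond the scatter), so quinolin-3-yl carries the number out of the measurable range even with trifluoromethyl present. From the compounds shown here alone, the true size of this step stays unknown, and the step for trifluoromethyl in place of hydrogen cannot be read, since both of its ends are limits. Both quinolin-3-yl compounds now end at the same limit: the limit of > 30000 nM in this assay, at which 2 of the 3 values shown sit.

Going by these compounds, what remains open is whether a smaller pyridin-3-yl or a 4-methoxyphenyl at this nitrogen would give a lower number than 4-chlorophenyl does. On these data alone, it is also open what 4-chlorophenyl gives with hydrogen in place of trifluoromethyl.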